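The source may hold more compounds than are shown below. What is called first, only, known or untested is meant among the compounds shown, and "the series" means these compounds.

In a functional assay on HeLa cells (Homo sapiens) for cytotoxicity, read by WST assay, with a stated time of 48 h (on this read-out higher numbers stand for weaker inhibition and lower numbers for stronger inhibition), compound 3 `COC[C@@H](C)[C@@H](C)C(c1ccc(O)c(OC)c1)c1ccc(O)c(OC)c1` gives only a limit, > 100000 nM, and no number. Compound 1 `COC[C@H](C(C)C)C(c1ccc(O)c(OC)c1)c1ccc(O)c(OC)c1` reads 76000 nM, and compound 2 `COc1cc(C(c2ccc(O)c(OC)c2)[C@@H](C)[C@@H](C)CF)ccc1O` reads 42000 nM. Those two are separated by a 1.8-fold lower number from compound 1 to compound 2 (0.26 log units; within the scatter). Compound 4 `COc1cc(C(c2ccc(O)c(OC)c2)[C@H](CO)C(C)C)ccc1O` carries 1-(hydroxymethyl)-2-methylpropyl in place of 2-(methoxymethyl)-1-methylpropyl on a saturated chain carbon bound to two aromatic carbons. The measured steps bearing on this change are an at least 1.3-fold higher number from compound 1 to compound 3 (0.11 log units; that floor lies within the scatter) and an at least 2.3-fold higher number from compound 2 to compound 3 (0.37 log units; beyond the scatter). Compound 1, with 1-(methoxymethyl)-2-methylpropyl, is the closest measured relative of compound 4, so a small move towards a lower number is expected, close to the scatter: an at least 1.5-fold lower number from compound 3 to compound 4 (0.18 log units; that floor lies within the scatter). For compound 4 the estimated value is 65000 nM, with an expected range of 30000 nM to 130000 nM.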

Compound 4, half-maximal inhibitory concentration: > 100000 nM
Compound 4 ended at the assay's limit (the forecaster's own chance of this, stated with the estimate: 35%); middle value at least 1.5-fold (0.18 log units) from the limit.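

In this assay compound 4 gives > 100000 nM as a limit and not a number, and this position now holds a second compound there: the limit of > 100000 nM in this assay, at which 2 of the 4 values shown sit. Hydrogen in place of methyl on the oxygen brings no reading under that limit (an at least 1.3-fold higher number from compound 1 to compound 4 (0.11 log units; that floor lies within the scatter)). The 2-(fluoromethyl)-1-methylpropyl chain of compound 2 stays apart from the 1-(hydroxymethyl)-2-methylpropyl chain (an at least 2.3-fold higher number from compound 2 to compound 4 (0.37 log units; beyond the scatter)).

The step between compound 3 and compound 4 cannot be read. On these data alone, whether an amine or a carboxylic acid on this chain would give a number under the limit stays open.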